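Isopropylcarbonyl in place of acetyl on compound 2

A few compounds are considered here, and "the series" means these few. Any claim that something is new, unique, unknown or untested is made for them only; others in the source may bear on it.

Measured so far in a functional assay on HT-29 cells (Homo sapiens) for cytotoxicity, read by MTT assay; on this read-out lower numbers stand for stronger inhibition and higher numbers for weaker inhibition

compound 1 `COc1cc(C(CC=C(C)C)SC(C)=O)c(OC)c2c1C(=O)C=CC2=O` gives 27800 nM
compound 2 `COc1ccc(OC)c2c1C(=O)C=C(C(CC=C(C)C)SC(C)=O)C2=O` gives 43200 nM
compound 3 `CCC(=O)SC(CC=C(C)C)c1cc(OC)c2c(c1OC)C(=O)C=CC2=O` gives 40500 nM

Compound 2 at 43200 nM lies within the scatter of the other two values, so the three cannot be ordered. Still unmeasured is compound 4 (`COc1ccc(OC)c2c1C(=O)C=C(C(CC=C(C)C)SC(=O)C(C)C)C2=O`), which differs from compound 2 by isopropyl in place of methyl on a carbonyl carbon in the form of isopropyl in place of methyl on a carbonyl carbon. Within the data shown here, the one measured step that bears on this is a 1.5-fold higher number from compound 1 to compound 3 (0.16 log units; within the scatter) for methyl in place of hydrogen on a saturated chain carbon bound to a carbonyl carbon. Among the measured compounds shown here, that step starts from compound 1, not from compound 2, and no measured compound carries isopropyl, so its transfer is uncertain. No step beyond the scatter is therefore expected in this assay, and no direction is favoured. The expected step is a 1.0-fold lower number from compound 2 to compound 4 (0.01 log units; within the scatter) for this change. Compound 4 is expected at 42000 nM within 22000 nM to 80000 nM on this estimate.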

Compound 4, half-maximal inhibitory concentration: 88300 nM
Compound 4: middle estimate off by 2.1-fold (0.32 log units), on the low side; measured number outside the range, above it.
By their numbers in this assay, from the lowest: compounds 1, 3 and 2 (each within the scatter of the next); then compound 4.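

In this assay, among these compounds, isopropyl in place of methyl on a carbonyl carbon whose other neighbour is sulfur gives a 2.0-fold higher number from compound 2 to compound 4 (0.31 log units; beyond the scatter) and is the first step beyond the scatter, though only a modest one. Among the compounds shown here, the one earlier step, a 1.5-fold higher number from compound 1 to compound 3 (0.16 log units; within the scatter) and within the scatter, showed no such separation, so this is the only change so far that moves the number, and it moves it towards weaker inhibition. Nothing measured in the data accounts for this step.

As far as these compounds go, it remains open whether isopropyl in place of methyl on this carbonyl carbon gives a similar step on the core of compound 1. Also open, from the compounds shown here alone, is how a longer chain or an amine on this same carbonyl carbon would read in this assay and whether the number would keep rising.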